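This account rests on a few compounds, and the source may have more. Where it says the series, first, only, none or still open, it means among the compounds named here.

Working notes on the series in an assay on RBL-1 cells for inhibition of Polyunsaturated fatty acid 5-lipoxygenase (Rattus norvegicus); a lower number here means a stronger inhibitor, a higher number a weaker inhibitor. Compound 1 `O=C(/C=C\N(O)Cc1ccccc1)c1ccc([N+](=O)[O-])cc1` gives 2500 nM in this assay. Compound 2 `CC(=O)N(/C=C\C(=O)C(C)(C)C)OCc1ccccc1` reaches only > 25000 nM in this assay, which is a limit of the assay and not a number, as recorded in the limit of > 25000 nM in this assay, at which 1 of the 3 values shown sits. Compound 3 `O=C(/C=C\N(O)Cc1ccc(-c2ccccc2)cc1)c1ccsc1` gives 3000 nM in this assay. Of the two measured numbers, compound 3 carries the higher one, but its nearest neighbour compound 1 sits at a gap that lies within the scatter, so the two values cannot be placed in any order.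

Compound 4 `O=C(/C=C\N(O)Cc1ccc(-c2ccccc2)cc1)c1cccs1` keeps every atom of compound 3 and joins them differently: thiophen-2-yl in place of thiophen-3-yl on a carbonyl carbon. Among the compounds with values here, no step between two measured compounds in the set bears on this change, and nothing in the set points to a direction for it, so the working expectation is a step of no consequence beyond the scatter.

The expected step is a 1.2-fold lower number from compound 3 to compound 4 (0.08 log units; within the scatter), estimated to stay within the scatter of repeated measurements. Compound 4 is therefore expected to land near 2500 nM in this assay, with a range estimated from 1000 nM to 6500 nM.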

Compound 4, half-maximal inhibitory concentration: > 25000 nM
Compound 4: no number, only a limit; the forecaster's own chance of this, stated with the estimate: 5%; middle value at least 10-fold (1.00 log units) from the limit.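

In this assay, within the data shown here, thiophen-2-yl in place of thiophen-3-yl on a carbonyl carbon gives an at least 8.3-fold higher number from compound 3 to compound 4 (0.92 log units; beyond the scatter), the only step that can be read across a single place. The two groups have the same atoms and the same counted features, so the way the thiophene ring is joined to this carbonyl carbon is enough on its own to separate the pair, something compound 1, compound 2 and compound 3, which differ from one another in more than one place, could not show. Compound 4 gives > 25000 nM, which is a limit of the assay and not a number: the limit of > 25000 nM in this assay, at which 2 of the 4 values shown sit.

The true size of the step stays open, and no measured property in the set accounts for it. Also open, on these data alone, is whether the step is specific to the thiophene rings or extends to furan-2-yl or pyridin-2-yl on the same carbonyl carbon, and whether it persists when the rest of the molecule differs from that of compound 3.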